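A few compounds are considered here, and "the series" means these few. Any claim that something is new, unique, unknown or untested is made for them only; others in the source may bear on it.

Measured compounds:
Compound 1 `CS(=O)(=O)Oc1c(C(=O)NCc2ccc(F)cc2)nc(Br)c2cccnc12` — in a functional assay on HCT-116 cells (Homo sapiens) for cytotoxicity, read by MTT assay, with a stated time of 72 h (a higher number here means a weaker inhibitor, a lower number a stronger inhibitor), compound 1 gives > 20000 nM.
Compound 2 `N[C@H]1CC[C@H](Nc2c(C(=O)NCc3ccccn3)nc(Br)c3cccnc23)CC1` — compound 2 gives "not determined" (no result reported).
Compound 3 `N[C@H]1CC[C@H](Nc2c(C(=O)NCc3cccs3)nc(Br)c3cccnc23)CC1` — compound 3 gives "not determined" (no result reported).

Compound 1 stands at the limit of > 20000 nM in this assay, at which 1 of the 3 values shown sits, and this is a limit of the assay rather than a number. Among the measured compounds shown here, compounds 2 and 3 carry no result, so no measured step between compounds exists here. Compound 4 `CNc1c(C(=O)NCc2ccc(F)cc2)nc(Br)c2cccnc12` differs from compound 1 by methylamino in place of (methylsulfonyl)oxy on an aromatic carbon. For the measured compounds named here, with only a limit for compound 1 and no measured step to lean on, the data give no direction for this change. The expected step of a number no higher from compound 1 to compound 4 (the limit leaves the size open) lies within the scatter, and a limit is again thought likely. Compound 4 is expected to give 20000 nM in this assay, within a range from 5000 nM to 50000 nM.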

Compound 4, half-maximal inhibitory concentration: > 20000 nM
Compound 4 ended at the assay's limit; the forecaster's own chance of this, stated with the estimate: 60%; the middle value lies on the limit itself.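

Among the compounds shown here, compound 1 and compound 4 both stand at a limit rather than a number, so no step between them can be read. The compounds shown leave open whether methylamino and (methylsulfonyl)oxy differ at all in their effect on these cells.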